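The source may hold more compounds than are shown below. What is called first, only, known or untested is meant among the compounds shown, and "the series" means these compounds.

Working notes on the series.

Of the compounds shown here, three share a core and have been measured in a functional assay on CAKI-1 cells (Homo sapiens) for inhibition, read by sulforhodamine B assay, with a stated time of 48 h; on this read-out higher numbers stand for weaker inhibition of growth and lower numbers for stronger inhibition of growth. Compound 1 `COc1ccc(CNc2nc3cc(N)cc(N)c3nc2-c2ccccc2)cc1OC` gives 11200 nM. Compound 3 `COc1cc(CNc2nc3cc(N)cc(N)c3nc2-c2ccccc2)cc(OC)c1OC` gives 1910 nM. Compound 2 `CCOC(=O)[C@H](CCC(=O)O)NC(=O)c1ccc(Sc2nc3cc(N)cc(N)c3nc2-c2ccccc2)cc1`, which carries a different linker and a different side chain, gives 79400 nM. Among these three numbers compound 1 sits second highest: compound 3 lies nearest with a lower number, and compound 2 lies furthest with a higher one.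

One step between single-point neighbours is known: a 5.9-fold lower number from compound 1 to compound 3 (0.77 log units; beyond the scatter), where a methoxy replaces a hydrogen on an aromatic carbon. Compound 2 differs from compound 1 in more than one place, so only its value is noted.

Compound 4 `COc1ccc(CNc2nc3cc(N)cc(N)c3nc2-c2ccccc2)cc1` is not yet measured. Its change from compound 1 is hydrogen in place of methoxy on an aromatic carbon. For the measured compounds named here, this is the reverse sense of the one known step, which removed a methoxy rather than added one. If adding a methoxy lowered the number, taking one away is expected to raise it, though the position differs and the size need not match. The expected step is a 2.2-fold higher number from compound 1 to compound 4 (0.35 log units; beyond the scatter), moderate and beyond the scatter.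

The estimate for compound 4 in this assay is 25000 nM, with a range from 8000 nM to 80000 nM.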

Compound 4, concentration for 50% growth inhibition: 16200 nM
For compound 4 the middle estimate is 1.5-fold (0.19 log units) above the measured one, within the range that was stated.
By their numbers in this assay, from the lowest: compound 3; then compounds 1 and 4 (each within the scatter of the next); then compound 2.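

In this assay, the step on replacing methoxy with hydrogen is a 1.4-fold higher number from compound 1 to compound 4 (0.16 log units; within the scatter), so the change from 3,4-dimethoxyphenyl to 4-methoxyphenyl leaves compounds 1 and 4 within the scatter of each other. At this carbon, ortho to a methoxy group and meta to a large group, the methoxy therefore shows no readable contribution to the number, whereas the other methoxy step on this ring, a 5.9-fold lower number from compound 1 to compound 3 (0.77 log units; beyond the scatter), lies beyond the scatter, so a methoxy change on this ring does not read the same at every carbon. No measurement at hand bears on the reason for this contrast.

On these data alone, it remains open whether this carbon tolerates groups of other kinds in the same way, for example a hydroxyl, a fluorine, an amine or a longer ethoxy chain, or whether the flat reading holds only for the swap of methoxy and hydrogen. Also open, as far as these compounds go, is what happens when the remaining methoxy of compound 4 gives way to hydrogen, leaving a plain phenyl ring.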